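This account rests on a few compounds, and the source may have more. Where it says the series, first, only, none or still open, it means among the compounds named here.

Measured compounds in an assay on cell membranes for binding affinity to Adrenergic receptor alpha-1 (Rattus norvegicus), read by radioligand binding; on this read-out higher numbers stand for weaker inhibition and lower numbers for stronger inhibition:
- compound 1, `COc1ccccc1N1CCN(CCCn2ncc(N3CCN(C(=O)c4ccco4)CC3)c(Cl)c2=O)CC1`: 20.4 nM
- compound 2, `O=C(c1ccco1)N1CCN(c2cnn(CCCN3CCN(c4ccccc4Cl)CC3)c(=O)c2Cl)CC1`: 3.5 nM
- compound 3, `COc1ccccc1N1CCN(CCn2nc(N3CCN(C(=O)c4ccco4)CC3)ccc2=O)CC1`: 94.5 nM

Compound 1 and compound 2 share a core; the only difference is chloro in place of methoxy on an aromatic carbon. That single change gave a 5.8-fold lower number from compound 1 to compound 2 (0.77 log units; beyond the scatter). Compound 3 carries the methoxy variant on a different core; the difference between the two cores is not broken down here, and compound 3 shows the highest number of the three, with compound 1 nearest and compound 2 furthest.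

Compound 4, `O=C(c1ccco1)N1CCN(c2ccc(=O)n(CCN3CCN(c4ccccc4Cl)CC3)n2)CC1`, has not been measured in this assay. It stands to compound 3 as compound 2 stands to compound 1: the change is chloro in place of methoxy on an aromatic carbon. The place is described in the same words for both pairs, so this is the same change made on the other core.

The expectation for compound 4 rests on a single precedent: the step from compound 1 to compound 2 in this assay, a 5.8-fold lower number from compound 1 to compound 2 (0.77 log units; beyond the scatter). Whether the other core carries the change to the same extent is not shown by any measured pair, so a step of about the same size but with wider uncertainty is expected, a 4.7-fold lower number from compound 3 to compound 4 (0.67 log units; beyond the scatter). Compound 4 is accordingly estimated at 20 nM in this assay, with a plausible range from 8 nM to 50 nM.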

Compound 4, inhibition constant: 34 nM
Beside the measured number, compound 4's estimate is 1.7-fold (0.23 log units) below it; measured number inside the range.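

In this assay, replacing 2-methoxyphenyl with 2-chlorophenyl on the core of compound 3 gives a 2.8-fold lower number from compound 3 to compound 4 (0.44 log units; beyond the scatter), so the number falls in the same direction as it did on the core of compound 1. Set side by side, the two steps cannot be told apart in size: the same change on two cores in this assay, a 5.8-fold lower number (0.77 log units; beyond the scatter) from compound 1 to compound 2 and a 2.8-fold lower number (0.44 log units; beyond the scatter) from compound 3 to compound 4, 2.1-fold (0.32 log units) apart, within the scatter of two such steps For this series, the change therefore carries across these two cores in direction, and the data give no sign that either core takes it more strongly, but two pairs do not establish a constant step and say nothing about any third core.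

The compounds shown leave open whether another group on the same aromatic carbon, such as fluoro, methyl or trifluoromethyl, would follow the chloro in this assay on both cores. Also open is how much of the gap between the two cores comes from each place in which they differ, as no pair shown separates these, and whether the step would hold with a longer chain on either core.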